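The source may report more compounds than this note shows. Statements on the series, on what has been measured and on what is new or still open speak of the compounds shown alone.

Compound 1 has the structure `N=S1(=O)c2ccccc2C(=O)N1c1ccccc1`. Going by the values given here, in an ADME assay on microsomes from liver (Homo sapiens) for metabolic stability (a higher number here means faster removal of the compound, a lower number slower removal), compound 1 gives 93.5 mL.min-1.g-1, and this is the only full number in the set. The second measured compound, compound 2, has the structure `CCNC1=NS(=O)(=O)c2ccccc21`. Compound 2 is reported in this assay only as a limit of the assay, < 3 mL.min-1.g-1, and not as a number. The picture so far is therefore (the limit of < 3 mL.min-1.g-1 in this assay, at which 1 of the 2 values shown sits), with compound 1 standing alone as the measured figure.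

The compound not yet measured, compound 3, has the structure `CCN1C(=O)c2ccccc2S1(=N)=O`. It differs from compound 1 in one place: ethyl in place of phenyl on an amide-type nitrogen in a ring.

Among the compounds with values here, no step between two measured compounds with this change is available, so the direction and size of the step from compound 1 to compound 3 cannot be read from a measured pair. The step is expected to go downward, toward slower removal, and to be larger than the usual scatter, by an estimated 3.1-fold lower number from compound 1 to compound 3 (0.49 log units; beyond the scatter). Compound 3 is thus expected to show roughly 30 mL.min-1.g-1 in this assay, within a range of 8 mL.min-1.g-1 to 90 mL.min-1.g-1.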

Compound 3, intrinsic clearance in microsomes in the liver assay: < 3 mL.min-1.g-1
Compound 3: only a limit was reported; the forecaster's own chance of this, stated with the estimate: 15%; middle value at least 10-fold (1.00 log units) from the limit.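

Going by these compounds alone, in the liver assay, ethyl in place of phenyl on an amide-type nitrogen in a ring gives an at least 31-fold lower number from compound 1 to compound 3 (1.49 log units; beyond the scatter), so this one position alone separates the only full number in the set from the bottom of the assay's range. The value of compound 3 is a limit and not a number, which leaves the full size of the step unknown, and the set now gathers at that limit: the limit of < 3 mL.min-1.g-1 in the liver assay, at which 2 of the 3 values shown sit. In a physicochemical assay for acid dissociation, read by spectrophotometry, compound 1 gives 8.3 and compound 3 gives 8.9, which is a number 0.60 log units higher from compound 1 to compound 3 (beyond the scatter), a modest step beside the large one in the liver assay.

Within the data shown here, only this one pair carries the change, so it remains open whether a longer chain, a benzyl group or a chain bearing an amine on the same nitrogen would stay at the limit or move back toward the number of compound 1. A single pair also cannot tell whether the numbers in the liver assay and the physicochemical assay move together across the series or merely shift side by side here.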